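Cyclopentyl on the aromatic nitrogen of a leukotriene receptor ligand

The source may report more compounds than this note shows. Statements on the series, on what has been measured and on what is new or still open speak of the compounds shown alone.

For the measured compounds named here, compound 1 `COc1cc(C(=O)NS(=O)(=O)c2ccccc2)ccc1Cc1c[nH]c2ccc(NC(=O)OC3CCCC3)cc12` is one of two compounds measured in an assay on lung parenchyma (Cavia porcellus) for displacement of a labelled ligand from cysteinyl leukotriene receptor (Homo sapiens) (on this read-out lower numbers stand for stronger inhibition and higher numbers for weaker inhibition), and in that assay compound 1 gives 1.4 nM, the lowest of the two numbers. The other measured compound, compound 2 `CCCn1cc(Cc2ccc(C(=O)O)cc2OC)c2cc(NC(=O)CC3CCCC3)ccc21`, differs from compound 1 in several places at once, and in this assay compound 2 gives 84 nM, a number well beyond the scatter of that of compound 1. Going by the values given here, since the two structures differ in more than one place, those values show only that compound 2 is the weaker binder of the pair, and nothing about any single change.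

The unmeasured compound 3 `COc1cc(C(=O)NS(=O)(=O)c2ccccc2)ccc1Cc1cn(C2CCCC2)c2ccc(NC(=O)OC3CCCC3)cc12` departs from compound 1 by one change: cyclopentyl in place of hydrogen on an aromatic nitrogen. Among the compounds with values here, no comparable single step between measured compounds is available here. For the step from compound 1 to compound 3 a modest loss in this assay is expected, a 2.9-fold higher number from compound 1 to compound 3 (0.46 log units; beyond the scatter), though a result within the scatter would not be surprising. Compound 3 is therefore estimated at 4 nM in this assay, within a range of 1 nM to 20 nM.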

Compound 3, inhibition constant: 67 nM
Beside the measured number, compound 3's estimate is 17-fold (1.22 log units) below it; the whole stated range lies below it.
By their numbers in this assay, from the lowest: compound 1; then compounds 3 and 2 (each within the scatter of the next).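

In this assay, for the compounds shown here, cyclopentyl in place of hydrogen on the aromatic nitrogen gives a 48-fold higher number from compound 1 to compound 3 (1.68 log units; beyond the scatter) and so provides the first reading of a single change in this set, since the two earlier compounds differed in several places at once. The large size of this step shows that this position is not indifferent to substitution: with the rest of compound 1 held constant, this one group on the nitrogen accounts for the whole of the loss in binding, and the hydrogen cannot be exchanged for cyclopentyl without that cost. No measurement among those available bears on why this change costs so much.

On these data alone, one group on one core cannot show whether the loss follows from replacing the hydrogen as such or from cyclopentyl in particular, so it remains open how a methyl, a propyl or a longer chain ending in a carboxylic acid would fare on the same nitrogen. As far as these compounds go, it is equally open whether the step would be of similar size if the benzenesulfonyl amide of compound 1 were replaced by a carboxylic acid.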